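The compounds below may be only part of what the source reports. "The series", "measured", "known", "first", "only" and "open" are said of these compounds alone.

Going by the values given here, in a functional assay on Hep 3B2 cells (Homo sapiens) for antiproliferative activity, read by MTT assay, with a stated time of 24 h (a lower number here means a stronger inhibitor, a higher number a weaker inhibitor), compound 1 `CCc1ccc2nc(C(=O)Nc3c(F)cc(-c4cccc(F)c4)cc3F)c(C)c(C(=O)O)c2c1` gives 16900 nM and compound 2 `Cc1c(C(=O)Nc2c(F)cc(-c3cccc(F)c3)cc2F)nc2ccc(F)cc2c1C(=O)O` gives 14700 nM, so compound 2 stands within the scatter of the only other compound measured so far. Compound 3 `COc1ccc2nc(C(=O)Nc3c(F)cc(-c4cccc(F)c4)cc3F)c(C)c(C(=O)O)c2c1` has methoxy in place of fluoro on an aromatic carbon. Among the compounds with values here, the one measured step at this same place, a 1.1-fold lower number from compound 1 to compound 2 (0.06 log units; within the scatter), swapped fluoro in for ethyl and lies within the scatter, so no step beyond the scatter is expected in this assay. The expected change is small: a 1.1-fold higher number from compound 2 to compound 3 (0.04 log units; within the scatter). For compound 3 the estimated value is 16000 nM, with an expected range of 7500 nM to 34000 nM.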

Compound 3, half-maximal inhibitory concentration: 14300 nM
Compound 3: the middle estimate sits 1.1-fold (0.05 log units) above what was measured, and the stated range covers the measured number.
By their numbers in this assay, from the lowest: compounds 3, 2 and 1 (each within the scatter of the next).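

In this assay this aromatic carbon has now carried ethyl, fluoro and methoxy, and all three steps stay within the scatter. Methoxy in place of fluoro gives a 1.0-fold lower number from compound 2 to compound 3 (0.01 log units; within the scatter) and methoxy in place of ethyl gives a 1.2-fold lower number from compound 1 to compound 3 (0.07 log units; within the scatter), so the one hydrogen-bond acceptor that methoxy counts brings no readable step here. Nothing measured accounts for this flat result. On these data alone, whether an amine, a carboxylic acid or a longer chain on this carbon would produce a step beyond the scatter stays open. So does whether the same flatness would hold with another part of the shared core changed.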